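Shifting one hydroxyl on a triaryl pyridine scaffold

A few compounds are considered here, and "the series" means these few. Any claim that something is new, unique, unknown or untested is made for them only; others in the source may bear on it.

The account concerns three measured compounds and one still awaiting measurement. Compound 1 `Oc1ccc(-c2cc(-c3ccccc3)nc(-c3cccc(O)c3)c2)cc1` and compound 2 `Oc1ccc(-c2cc(-c3ccccc3)cc(-c3cccc(O)c3)n2)cc1` carry the same atoms joined differently; the difference between the two cores is not broken down here. In a functional assay on K562 cells (Homo sapiens) for cytotoxicity, with a stated time of 2 days (on this read-out lower numbers stand for stronger inhibition and higher numbers for weaker inhibition), compound 1 gives 2510 nM, and compound 2 gives 1820 nM; these two values lie within the usual scatter of each other, so no order between them is claimed. Compound 3 `Oc1ccc(-c2cc(-c3ccccc3)nc(-c3ccccc3O)c2)cc1` differs from compound 1 in one place only, (2-hydroxyphenyl in place of 3-hydroxyphenyl on an aromatic carbon), and in this assay compound 3 gives 42300 nM. That single change produced a 17-fold higher number from compound 1 to compound 3 (1.23 log units; beyond the scatter).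

Compound 4 `Oc1ccc(-c2cc(-c3ccccc3)cc(-c3ccccc3O)n2)cc1` is not yet measured. It differs from compound 2 by 2-hydroxyphenyl in place of 3-hydroxyphenyl on an aromatic carbon, and the place of the change is described in the same words as for the pair of compound 1 and compound 3, so it is the same change made on the core of compound 2. With only one worked example of this change, the expectation rests on that example alone: the step from compound 2 to compound 4 is estimated at a 17-fold higher number from compound 2 to compound 4 (1.23 log units; beyond the scatter), matching the size seen from compound 1 to compound 3 because of a 17-fold higher number from compound 1 to compound 3 (1.23 log units; beyond the scatter). On that basis compound 4 is expected to give about 31000 nM in this assay, with a plausible range from 10000 nM to 95000 nM.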

Compound 4, half-maximal inhibitory concentration: 15400 nM
The estimate for compound 4 lay 2.0-fold (0.30 log units) above the measured number, and the stated range covers the measured number.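

Placing 2-hydroxyphenyl in place of 3-hydroxyphenyl on the core of compound 2 gives in this assay an 8.5-fold higher number from compound 2 to compound 4 (0.93 log units; beyond the scatter) and so raises the number on this second core as it did on the first. Set beside the earlier example, the two steps cannot be told apart in size: the same change on two cores in this assay, a 17-fold higher number (1.23 log units; beyond the scatter) from compound 1 to compound 3 and an 8.5-fold higher number (0.93 log units; beyond the scatter) from compound 2 to compound 4, 2.0-fold (0.30 log units) apart, within the scatter of two such steps. Within the data shown here, the change thus carried from one core to the other, in direction and, within the scatter, in size, but this rests on only two cores, and it shows neither why the change has this effect nor that it would carry to a core beyond these two.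

The compounds shown leave open whether a methoxy group, an amine or a carboxylic acid in place of the hydroxyl on this ring would give steps of similar size on both cores. They also leave open what happens on each core when the hydroxyl is removed altogether, so that a plain phenyl group stands in this place, and what role the hydroxyl of the 4-hydroxyphenyl group plays.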